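Triazolylthio-naphthol amides: change at the carbonyl carbon

A few compounds are considered here, and "the series" means these few. Any claim that something is new, unique, unknown or untested is made for them only; others in the source may bear on it.

Measured so far in an assay on isolated protein for inhibition of RAC-alpha serine/threonine-protein kinase (Homo sapiens), read by fluorescence, with a stated time of 30 min, tested at 10 uM; a higher number here means more inhibition at the concentration tested (going by the name of the read-out), a lower number less inhibition:
compound 1 `Cc1cccc(C(=O)Nc2cc(Sc3ncn[nH]3)c(O)c3ccccc23)c1` gives 20.2%;
compound 2 `O=C(Nc1cc(Sc2ncn[nH]2)c(O)c2ccccc12)c1ccc2ccccc2c1` gives 41.6%;
compound 3 `O=C(Nc1cc(Sc2ncn[nH]2)c(O)c2ccccc12)c1ccc([N+](=O)[O-])cc1` gives 37.3%.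

Compound 3 stands second highest of the three numbers. Its nearest neighbour is compound 2, and the step of a number 4.3 percentage points lower from compound 2 to compound 3 (within the scatter) lies within the scatter, so no order between compound 2 and compound 3 can be claimed. The step of a number 17.1 percentage points higher from compound 1 to compound 3 (beyond the scatter) is beyond the scatter, as is a number 21.4 percentage points higher from compound 1 to compound 2 (beyond the scatter), so both changes away from 3-methylphenyl on the carbonyl carbon gave a modest gain.

Compound 4 `O=C(/C=C/c1ccccc1)Nc1cc(Sc2ncn[nH]2)c(O)c2ccccc12` is not yet measured. It differs from compound 3 as follows: 2-phenylethenyl in place of 4-nitrophenyl on a carbonyl carbon. Going by the values given here, all three measured steps alter the same group on the carbonyl carbon, and together they show that this group moves the read-out by modest amounts only; none of them tests a 2-phenylethenyl group, so no direct precedent exists. The number for compound 4 is therefore expected to fall near compound 3 or somewhat lower, a step of about a number 7.3 percentage points lower from compound 3 to compound 4 (within the scatter).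

For compound 4 the estimate in this assay is 30%, with an expected range from 12% to 50%.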

Compound 4, a percentage reported as inhibition, at one concentration (the size of the read-out at that concentration, not a potency): 26.2%
Compound 4: middle estimate off by 3.8 percentage points, on the high side, and the stated range covers the measured number.
By their numbers in this assay, from the lowest: compounds 1 and 4 (each within the scatter of the next); then compounds 3 and 2 (each within the scatter of the next).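

In this assay, going by these compounds alone, 2-phenylethenyl on the carbonyl carbon is the first group at this position to fall short of both 4-nitrophenyl (a number 11.1 percentage points lower from compound 3 to compound 4 (beyond the scatter)) and naphthalen-2-yl (a number 15.4 percentage points lower from compound 2 to compound 4 (beyond the scatter)). Against 3-methylphenyl it shows no separation (a number 6 percentage points higher from compound 1 to compound 4 (within the scatter)), so the four compounds now form two levels: compound 1 with compound 4, and compound 2 with compound 3, with modest steps between the levels and no order within either. No measured evidence accounts for these steps.

Whether the double bond of 2-phenylethenyl matters remains open, as the saturated 2-phenylethyl group does not appear among these compounds. Also open, on these data alone, is where an amine, a carboxylic acid or a longer alkyl chain on the carbonyl carbon would fall relative to these two levels.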